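The compounds below may be only part of what the source reports. "The series", "measured", "known", "first", "only" and "open" are said of these compounds alone.

Measured compounds:
- compound 1, `O=C(Nc1cccc(F)c1)C(Cl)Cl`, which gives "not determined" (no result reported) in a functional assay on BGC-823 cells (Homo sapiens) for antiproliferative activity, read by MTT assay, with a stated time of 72 h; a higher number here means a weaker inhibitor, a lower number a stronger inhibitor
- compound 2, `O=C(Nc1cccc(Br)c1)C(Cl)Cl`, which gives 95300 nM in this assay
- compound 3, `N#Cc1cccc(NC(=O)C(Cl)Cl)c1`, which gives "not determined" (no result reported) in this assay

The three compounds share one dichloroacetamide core and differ only in the group on the aromatic ring. Compound 3 stands without a single number in this assay; compound 1 is in the same position, with no result reported. For the measured compounds named here, the only number among the three belongs to compound 2, and it is a high one, which in this assay means a weak inhibitor.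

The step to compound 4, `O=C(Nc1cccc(C(F)(F)F)c1)C(Cl)Cl`, is trifluoromethyl in place of cyano on an aromatic carbon. Going by the values given here, no step between two measured compounds is available to calibrate this change, so the only guide is the weak value of compound 2 for the shared core. The expectation is therefore a step in this assay of no more than modest size in either direction, most likely none beyond the usual scatter. On that basis compound 4 is expected to give about 80000 nM in this assay, with a likely range from 20000 nM to 300000 nM.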

Compound 4, half-maximal inhibitory concentration: 143000 nM
Estimate against measurement, compound 4: 1.8-fold (0.25 log units) below; the measured number falls inside the stated range.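

In this assay, for the compounds shown here, trifluoromethyl in place of bromo on the same aromatic carbon gives a 1.5-fold higher number from compound 2 to compound 4 (0.18 log units; within the scatter), so the two groups cannot be told apart at this position, and this pair gives the first comparison between measured compounds. The change from cyano to trifluoromethyl cannot be read, as compound 3 has no single number to set against compound 4. No measurement shown here offers an explanation for how close the two values lie.

From the compounds shown here alone, whether a very different group at this position, such as an amine or a carboxylic acid, would give a step beyond the scatter remains open. Going by these compounds alone, with only two numbers in hand, no trend across groups can be claimed for the shared core.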